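A Tert-Butyl Group Added to Compound 1

The source may hold more compounds than are shown below. What is called first, only, known or untested is meant among the compounds shown, and "the series" means these compounds.

Measured in a functional assay on A549 cells (Homo sapiens) for antiproliferative activity, read by MTT assay, with a stated time of 72 h; a lower number here means a stronger inhibitor, a higher number a weaker inhibitor:

- compound 1 `S=C(Sc1ccccc1)N1CCCCC1` gives 7930 nM
- compound 2 `S=C(Sc1ccccc1)N1CCOCC1` gives 2520 nM

Compound 1 holds the higher of the two numbers, and compound 2 lies lower by a gap beyond the usual scatter. Compound 3 `CC(C)(C)c1ccc(SC(=S)N2CCCCC2)cc1` differs from compound 1 by tert-butyl in place of hydrogen on an aromatic carbon. Within the data shown here, no measured step covers this change, so only a slight lowering, not beyond the scatter, is expected in this assay for it. The expected change is a 1.6-fold lower number from compound 1 to compound 3 (0.20 log units; within the scatter) (an estimate). For compound 3 the expected value is 5000 nM (estimated range 1500 nM to 15000 nM).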

Compound 3, half-maximal inhibitory concentration: 9130 nM
Compound 3: middle estimate off by 1.8-fold (0.26 log units), on the low side; the measured number falls inside the stated range.
By their numbers in this assay, from the lowest: compound 2; then compounds 1 and 3 (each within the scatter of the next).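

In this assay, tert-butyl in place of hydrogen on an aromatic carbon, para to a group of 9 heavy atoms, gives a step that stays within the scatter (a 1.2-fold higher number from compound 1 to compound 3 (0.06 log units; within the scatter)). Among these compounds, compound 1 and compound 2 differ elsewhere in the molecule, so this is the first reading at this aromatic position, and this large group shifts the number by no more than the scatter. No evidence at hand bears on this result.

From the compounds shown here alone, whether an amine or a carboxylic acid at this position would give a step beyond the scatter stays open. So does the outcome of tert-butyl at this position on compound 2.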